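The source may hold more compounds than are shown below. What is called first, only, known or untested is meant among the compounds shown, and "the series" means these compounds.

In a functional assay on KYSE-450 cells (Homo sapiens) for inhibition, read by CCK-8 assay, with a stated time of 48 h (a higher number here means a weaker inhibitor, a lower number a stronger inhibitor), compound 3 `COc1ccc(CN(C(=O)CSC(=S)N2CCc3ccccc32)c2cc(OC)c(OC)c(OC)c2)cc1` gives 6940 nM, the highest number of the three measured and so the weakest inhibitor among them. Compound 1 `COc1ccc(CN(C(=O)CSc2nc3ccccc3o2)c2cc(OC)c(OC)c(OC)c2)cc1` gives 840 nM and compound 2 `COc1ccc(CN(C(=O)CSC(=S)N2CCN(C)CC2)c2cc(OC)c(OC)c(OC)c2)cc1` gives 1250 nM, a pair separated by a 1.5-fold higher number from compound 1 to compound 2 (0.17 log units; within the scatter). Compound 4 `COc1ccc(CN(C(=O)CSC(=S)N2CCc3cc(Br)ccc32)c2cc(OC)c(OC)c(OC)c2)cc1` differs from compound 3 by a single change, bromo in place of hydrogen on an aromatic carbon. Within the data shown here, no measured step adds a bromo group. The nearest evidence is a 5.6-fold higher number from compound 2 to compound 3 (0.74 log units; beyond the scatter) and an 8.3-fold higher number from compound 1 to compound 3 (0.92 log units; beyond the scatter), but each exchanges a whole group, far more than one hydrogen atom, so they give only an outer bound. In this assay the expected step is a 1.4-fold lower number from compound 3 to compound 4 (0.14 log units; within the scatter), and these data set no firm direction. For compound 4 the estimated value is 5000 nM, with an expected range of 1700 nM to 14000 nM.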

Compound 4, half-maximal inhibitory concentration: > 20000 nM
Compound 4 was reported as a limit; the forecaster's own chance of this, stated with the estimate: 5%; at least 4.0-fold (0.60 log units) between middle value and limit.
By their numbers in this assay, from the lowest: compounds 1 and 2 (each within the scatter of the next); then compound 3. At a limit, above all of these: compound 4.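

In this assay compound 4 is reported only as a limit: the limit of > 20000 nM in this assay, at which 1 of the 4 values shown sits. Adding one bromo to the six-membered aromatic ring, which turns 2,3-dihydro-1H-indol-1-yl into 5-bromo-2,3-dihydro-1H-indol-1-yl, gives an at least 2.8-fold higher number from compound 3 to compound 4 (0.45 log units; beyond the scatter), so a single heavy atom at this position weakens inhibition beyond the scatter. The whole-group exchanges now span more, with an at least 16-fold higher number from compound 2 to compound 4 (1.20 log units; beyond the scatter) and an at least 23-fold higher number from compound 1 to compound 4 (1.37 log units; beyond the scatter).

The compounds shown leave open how far the true value of compound 4 lies past its limit. They also leave open whether chloro, fluoro or methoxy at this position would weaken inhibition as bromo does.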